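Swapping a chlorine for a fluorine on the pendant phenyl ring

A few compounds are considered here, and "the series" means these few. Any claim that something is new, unique, unknown or untested is made for them only; others in the source may bear on it.

Of the compounds shown here, three sharing one core have been measured in a functional assay on PC-3 cells (Homo sapiens) for inhibition, read by sulforhodamine B assay, with a stated time of 48 h, tested at 10 uM; on this read-out higher numbers stand for more inhibition at the one concentration tested (going by the name of the read-out) and lower numbers for less inhibition. Compound 1 `COc1ccc(-c2cn3ccnc3c(-c3ccc4ncn(C5CCCCC5)c4c3)n2)cc1` gives 95.2%. Compound 2 `O=Cc1ccc(-c2cn3ccnc3c(-c3ccc4ncn(C5CCCCC5)c4c3)n2)cc1` gives 19%, and compound 3 `Clc1ccc(-c2cn3ccnc3c(-c3ccc4ncn(C5CCCCC5)c4c3)n2)cc1` gives 24.6%. Compound 3 therefore stands second of the three: it sits far below compound 1, since a number 70.6 percentage points lower from compound 1 to compound 3 (beyond the scatter), while its gap to compound 2 is small, as a number 5.6 percentage points higher from compound 2 to compound 3 (within the scatter). Compound 1 also stands far above compound 2, as a number 76.2 percentage points lower from compound 1 to compound 2 (beyond the scatter).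

Compound 4 `Fc1ccccc1-c1cn2ccnc2c(-c2ccc3ncn(C4CCCCC4)c3c2)n1` has not yet been measured. It differs from compound 3 in one place: 2-fluorophenyl in place of 4-chlorophenyl on an aromatic carbon. Among the compounds with values here, no measured step swaps one halogen for another on this phenyl ring, so the only guide is that chloro and formyl, two different groups at that position, gave numbers within the scatter of each other. Compound 4 is therefore expected to stay close to compound 3, with a number 5.4 percentage points higher from compound 3 to compound 4 (within the scatter) in this assay. The estimate for compound 4 is 30%, most likely between 10% and 60%.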

Compound 4, a percentage reported as inhibition, at one concentration (the size of the read-out at that concentration, not a potency): 32.6%
Compound 4: the middle estimate sits 2.6 percentage points below what was measured; measured number inside the range.
By their numbers in this assay, from the lowest: compounds 2, 3 and 4 (each within the scatter of the next, the first and the last beyond it); then compound 1.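

In this assay, the step to a 2-fluorophenyl group stays within the scatter (a number 8 percentage points higher from compound 3 to compound 4 (within the scatter)), although it changes both the halogen and where it sits on the phenyl ring, so neither change can be read alone. The same group does separate from 4-formylphenyl by a modest margin (a number 13.6 percentage points higher from compound 2 to compound 4 (beyond the scatter)), yet it falls far short of 4-methoxyphenyl (a number 62.6 percentage points lower from compound 1 to compound 4 (beyond the scatter)), which leaves compound 1 well above each of the other three. Nothing available explains these differences.

Going by these compounds, it remains open whether a high number depends on the methoxy group itself, or whether an ethoxy group, a hydroxyl group or an amine on the phenyl ring would also give one. The separate contributions of the halogen and its place on the ring also stay unresolved.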